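The source may report more compounds than this note shows. Statements on the series, on what has been measured and on what is new or still open speak of the compounds shown alone.

Values so far in an ADME assay on Vero cells (Chlorocebus sabaeus) for cytotoxicity, read by crystal violet staining, with a stated time of 72 h (a lower number here means that less compound is tolerated, a higher number that more compound is tolerated), for the series:

- compound 1 `COc1cc(-c2ccc(C(=O)NNC(=S)Nc3ccccc3)c(C)n2)cc(OC)c1OC` gives 513000 nM
- compound 2 `COc1ccc(NC(=S)NNC(=O)c2ccc(-c3ccc(OC)c(OC)c3)nc2C)cc1` gives 632000 nM
- compound 3 `COc1cc(-c2ccc(C(=O)NNC(=S)Nc3ccc(C)cc3)c(C)n2)cc(OC)c1OC` gives 574000 nM

Compound 3 at 574000 nM is not separated from compound 1 or compound 2, as all three values lie within the scatter of one another.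

Next comes compound 4 `COc1ccc(NC(=S)NNC(=O)c2ccc(-c3cc(OC)c(OC)c(OC)c3)nc2C)cc1` with methoxy in place of methyl on an aromatic carbon, para to a large group (methoxy in place of methyl on an aromatic carbon). The same difference reads 4-methylphenyl to 4-methoxyphenyl.

For the measured compounds named here, the one measured step at this aromatic carbon is a 1.1-fold higher number from compound 1 to compound 3 (0.05 log units; within the scatter) with methyl in place of hydrogen, and it lies within the scatter. Compound 2 already carries the 4-methoxyphenyl group but also differs elsewhere, and at 632000 nM it stays within the scatter of compound 3. A direct exchange of methyl for methoxy has not been measured.

On this evidence, the step expected is a 1.0-fold higher number from compound 3 to compound 4 (0.01 log units; within the scatter) and so none beyond the scatter in this assay with no direction favoured. For compound 4 the estimate is 590000 nM with an expected range from 400000 nM to 870000 nM for the measurement.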

Compound 4, half-maximal cytotoxic concentration: 506000 nM
The estimate for compound 4 lay 1.2-fold (0.07 log units) above the measured number; measured number inside the range.
By their numbers in this assay, from the lowest: compounds 4, 1, 3 and 2 (each within the scatter of the next).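

Working notes on the series: in this assay, the direct exchange of 4-methylphenyl for 4-methoxyphenyl now reads as a 1.1-fold lower number from compound 3 to compound 4 (0.05 log units; within the scatter) and stays within the scatter, and methoxy in place of hydrogen at the same aromatic carbon reads as a 1.0-fold lower number from compound 1 to compound 4 (0.01 log units; within the scatter) and also stays within the scatter. With the earlier methyl step, hydrogen, methyl and methoxy at this carbon are therefore not separated in this assay, and the series also gains a second place where a hydrogen gives way to a methoxy group, read as a 1.2-fold lower number from compound 2 to compound 4 (0.10 log units; within the scatter) and again within the scatter. No measurement bears on why these three exchanges leave the numbers unseparated.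

Going by these compounds, whether a different kind of group at this carbon, such as an amine or a carboxylic acid, would give a step beyond the scatter in this assay stays open. On these data alone, what a change to the shared core itself would do to the number in this assay also stays open, since all four compounds keep that core and differ only in their aromatic substituents.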